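Swapping a phenyl for thiophen-2-yl on a shared pyridine-type core

The source may hold more compounds than are shown below. What is called first, only, known or untested is meant among the compounds shown, and "the series" means these compounds.

Compound 2 `Oc1ccc(-c2cc(-c3ccccc3)cc(-c3ccccc3)n2)cc1` is a hydroxyphenyl-bearing member of this small set. In an assay on isolated protein for inhibition of DNA topoisomerase 1 (Homo sapiens), with a stated time of 30 min, tested at 100 uM (a lower number here means a weaker effect, a higher number a stronger effect of the compound at the concentration tested), compound 2 gives 52.9%. Compound 1 `Oc1cccc(-c2cc(-c3ccccc3)cc(-c3cccs3)n2)c1` carries a thiophen-2-yl group where compound 2 has a phenyl, and in this assay compound 1 gives 51.2%; the two numbers lie within the usual scatter of each other, so neither can be called stronger. Compound 3 `Oc1ccc(-c2cc(-c3ccccc3)cc(-c3cccs3)n2)cc1` has not been measured. It differs from compound 2 in one place: thiophen-2-yl in place of phenyl on an aromatic carbon. Since compound 1 gives 51.2% with the same thiophen-2-yl group, no step beyond the scatter is expected from compound 2 to compound 3, and the estimated change is a number 0.9 percentage points lower from compound 2 to compound 3 (within the scatter). The expected value for compound 3 is 52%, from 40% to 64%.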

Compound 3, a percentage reported as inhibition, at one concentration (the size of the read-out at that concentration, not a potency): 4.9%
Beside the measured number, compound 3's estimate is 47.1 percentage points above it; measured number outside the range, below it.
By their numbers in this assay, from the lowest: compound 3; then compounds 1 and 2 (each within the scatter of the next).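

In this assay, thiophen-2-yl in place of phenyl is far from neutral at this position beside a 4-hydroxyphenyl group, giving a number 48 percentage points lower from compound 2 to compound 3 (beyond the scatter). With thiophen-2-yl kept, 4-hydroxyphenyl in place of 3-hydroxyphenyl gives a number 46.3 percentage points lower from compound 1 to compound 3 (beyond the scatter), so the group tolerated in compound 1 is not tolerated in compound 3, and the two changes cannot be read apart from each other. Nothing shown explains this loss. From the compounds shown here alone, whether furan-2-yl or an amine at this position would restore the effect remains open.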